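A few compounds are considered here, and "the series" means these few. Any claim that something is new, unique, unknown or untested is made for them only; others in the source may bear on it.

Compound 1 `Cc1ccc2scc(CCC(=O)N3CCC[C@H](c4ccccc4)[C@@H]3CN3CCCC3)c2c1`: 3160 nM
Compound 2 `CCN(CC(=O)N1CCC[C@H](c2ccccc2)[C@@H]1CN1CCCC1)c1ccc(Cl)c(Cl)c1`: 31.6 nM
Compound 3 `Cc1ccc(N(C)CC(=O)N2CCC[C@H](c3ccccc3)[C@@H]2CN2CCCC2)cc1C`: 200 nM

These three values come from an assay on HEK293 cells for displacement of a labelled ligand from Urotensin-2 receptor (Homo sapiens); a lower number here means a stronger inhibitor, a higher number a weaker inhibitor. Among them compound 3 holds the middle number: compound 2 sits lower and compound 1 higher, both separations lie beyond the scatter, and compound 2 is the nearer neighbour. Compound 4 `CN(CC(=O)N1CCC[C@H](c2ccccc2)[C@@H]1CN1CCCC1)c1ccc2ccccc2c1` has not been measured; it differs from compound 3 in one place: naphthalen-2-yl in place of 3,4-dimethylphenyl on an amine nitrogen. Going by the values given here, no pair of measured compounds isolates this change, so its size can only be expected, not read off. A modest lowering of the number, close to the edge of the scatter, is expected, given as a 2.0-fold lower number from compound 3 to compound 4 (0.30 log units; within the scatter). For compound 4 the estimated value in this assay is 100 nM, within a range from 25 nM to 400 nM.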

Compound 4, inhibition constant: 158 nM
Compound 4: the middle estimate sits 1.6-fold (0.20 log units) below what was measured; measured number inside the range.
By their numbers in this assay, from the lowest: compound 2; then compounds 4 and 3 (each within the scatter of the next); then compound 1.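

In this assay, going by these compounds alone, the exchange of 3,4-dimethylphenyl for naphthalen-2-yl on the amine nitrogen is a 1.3-fold lower number from compound 3 to compound 4 (0.10 log units; within the scatter) and is the first step that can be read at this position. The place therefore takes 2 six-membered aromatic rings of carbon only, instead of one, with no change beyond the scatter. No measurement at hand bears on this result.

Open, on these data alone, is how a pyridine ring or a carboxylic acid on the aromatic ring would fare on this nitrogen. Also open, as far as these compounds go, is what an ethyl group in place of the methyl group on that nitrogen does with the aromatic group held fixed.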